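A few compounds are considered here, and "the series" means these few. Any claim that something is new, unique, unknown or untested is made for them only; others in the source may bear on it.

Compound 1 `CCOC(=O)c1cc([Se]Cc2ccccc2)c2cc(OC)ccc2n1`: 40700 nM
Compound 2 `CCOC(=O)c1cc([Se]c2ccc3ccccc3c2)c2cc(OC)ccc2n1`: 32200 nM

Both were tested in a functional assay on SK-MEL-147 cells (Homo sapiens) for cytotoxicity, read by MTT assay, with a stated time of 24 h (on this read-out lower numbers stand for an effect already at smaller amounts and higher numbers for an effect only at larger amounts of compound), and compound 1 stands level with compound 2, since their numbers lie within the usual scatter. Compound 3 `CCOC(=O)c1cc(C#CCCO)c2cc(OC)ccc2n1` keeps the core of compound 1 but changes the group opposite the ring nitrogen a group of 5 heavy atoms (4 carbon, 1 oxygen; no ring) in place of a group of 8 heavy atoms (7 carbon, 1 selenium; one six-membered aromatic ring of carbon only), on an aromatic carbon: the selenium-containing group leaves and 4-hydroxybut-1-yn-1-yl enters. For the measured compounds named here, no measured compound lacks selenium, so the guidance is thin. Starting from compound 1 at 40700 nM, a small move towards a higher number is expected, perhaps no larger than the scatter. The estimated change is a 1.6-fold higher number from compound 1 to compound 3 (0.20 log units; within the scatter). For compound 3 the estimate is 65000 nM, with an expected range of 25000 nM to 170000 nM.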

Compound 3, half-maximal effective concentration: > 150000 nM
Compound 3 gave a limit, no number; the forecaster's own chance of this, stated with the estimate: 25%; middle value at least 2.3-fold (0.36 log units) away from the limit.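

Compound 3 gives no number in this assay, only a limit: the limit of > 150000 nM in this assay, at which 1 of the 3 values shown sits. Putting 4-hydroxybut-1-yn-1-yl opposite the ring nitrogen in place of the selenium-containing group gives an at least 3.6-fold higher number from compound 1 to compound 3 (0.56 log units; beyond the scatter). This is the first step shown at this position, and it lies beyond the scatter, so the group held here does matter in this cell test.

Going by these compounds, how far the number of compound 3 lies past the limit remains unknown. Also open, on these data alone, is whether losing selenium or the aromatic ring counts more, which a benzylamine group at this position could help separate.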